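Biaryl tail exchange: lipophilicity notes on compounds 2 and 3

The source may report more compounds than this note shows. Statements on the series, on what has been measured and on what is new or still open speak of the compounds shown alone.

Measured so far:
compound 1 `CC[C@@H](Nc1c(C#N)c(-c2ccc(-c3cccc(C)c3)cc2)nc2cnccc12)C(N)=O` gives 3
compound 2 `CC[C@@H](Nc1c(C#N)c(-c2ccc(-c3cnccc3C)cc2)nc2cnccc12)C(N)=O` gives 2

In a physicochemical assay for lipophilicity, read by HPLC, at pH 7.5 (on this read-out higher numbers stand for higher lipophilicity and lower numbers for lower lipophilicity), compound 2 stands lowest of the two numbers; its nearest neighbour is compound 1, the step being a number 1.00 log units lower from compound 1 to compound 2 (beyond the scatter). Compound 3 `CC[C@@H](Nc1c(C#N)c(-c2ccc(-c3ccccc3C)cc2)nc2cnccc12)C(N)=O` differs from compound 2 by 2-methylphenyl in place of 4-methylpyridin-3-yl on an aromatic carbon. Among the measured compounds shown here, the single measured step that bears on this change is a number 1.00 log units lower from compound 1 to compound 2 (beyond the scatter), and the exchange from compound 2 to compound 3 runs the other way, a carbon ring for the nitrogen ring, so a step of similar size upward in this assay is expected. Compound 3 is therefore estimated at 3, within 2.6 to 3.4, an expected step of a number 1.00 log units higher from compound 2 to compound 3 (beyond the scatter).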

Compound 3, distribution coefficient: 3
The estimate for compound 3 equals the measured number at the digits printed; the range from low to high includes it.
By their numbers in this assay, from the lowest: compound 2; then compounds 1 and 3 (each within the scatter of the next).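

With 2-methylphenyl in place of 4-methylpyridin-3-yl, this assay shows a number 1.00 log units higher from compound 2 to compound 3 (beyond the scatter) at this position on the phenyl ring, so compound 2, with the nitrogen ring, now stands apart from two compounds with carbon-only rings. Moving the methyl, with 2-methylphenyl in place of 3-methylphenyl, gives no change at the digits printed from compound 1 to compound 3 (within the scatter) and so separates nothing here. No measured evidence accounts for these steps. Open, on these data alone, is how an unsubstituted phenyl ring would read at this position. Also open, as far as these compounds go, is whether a methoxy group, a dimethylamino group or a carboxylic acid in place of the methyl would read with compound 2 or with compound 3.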